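The source may report more compounds than this note shows. Statements on the series, on what has been measured and on what is new or still open speak of the compounds shown alone.

The shared core carries an amide-type ring nitrogen bearing an aryl group in the first three compounds. Compound 1 `COc1ncc(-c2ccc3c(c2)N(c2ccc(C)cc2)C(=O)CO3)cc1NS(=O)(=O)c1ccc(F)cc1` gives 22700 nM in a functional assay on HCT-116 cells (Homo sapiens) for antiproliferative activity, read by MTT assay, with a stated time of 72 h; on this read-out lower numbers stand for stronger inhibition and higher numbers for weaker inhibition. Among the compounds with values here, compound 2 `COc1ncc(-c2ccc3c(c2)N(c2ccc(Cl)cc2)C(=O)CO3)cc1NS(=O)(=O)c1ccc(F)cc1` gives 19200 nM in this assay, and the only measured single-point step, a 1.2-fold lower number from compound 1 to compound 2 (0.07 log units; within the scatter), shows that exchanging the substituent on that aryl ring leaves the read-out where it was. Compound 3 `O=C1COc2ccc(-c3cccc(NS(=O)(=O)c4ccc(F)cc4)c3)cc2N1c1ccc(F)cc1` moves the sulfonamide to another ring position and stands apart in this assay: compound 3 gives > 40000 nM, which is a limit of the assay and not a number. What is known of compound 3 is only (the limit of > 40000 nM in this assay, at which 1 of the 3 values shown sits), so it sits at the weak edge of what the numbers shown can resolve.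

Compound 4 `O=C1COc2ccc(-c3cccc(NS(=O)(=O)c4ccc(F)cc4)c3)cc2N1` differs from compound 3 in one place: hydrogen in place of 4-fluorophenyl on an amide-type nitrogen in a ring. Within the data shown here, no measured step concerns this change, since a 1.2-fold lower number from compound 1 to compound 2 (0.07 log units; within the scatter) alters only a substituent on the aryl group rather than removing the group. Compound 4 is therefore expected to stay close to where compound 3 lies, with a number no higher from compound 3 to compound 4 (the limit leaves the size open). Compound 4 is estimated at 40000 nM, with a range from 15000 nM to 120000 nM.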

Compound 4, half-maximal inhibitory concentration: > 40000 nM
Compound 4: a limit, no number (the forecaster's own chance of this, stated with the estimate: 65%); the middle value lies on the limit itself.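

No step can be read between compound 3 and compound 4, as each is known in this assay only as a limit, so the exchange of 4-fluorophenyl for hydrogen has no readable size. The compounds shown leave open how weak compound 3 and compound 4 really are, and whether that exchange changes the read-out at all: the limit of > 40000 nM in this assay, at which 2 of the 4 values shown sit.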